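The compounds below may be only part of what the source reports. "The series", "measured", "known", "first", "only" and "open" are said of these compounds alone.

In a functional assay on the whole organism (Hindlimb, strain albino) with Mus musculus as the target, in the maximal electroshock model, with a stated time of 0.5 h (on this read-out higher numbers stand for an effect only at larger amounts of compound and lower numbers for an effect already at smaller amounts), three compounds have been measured so far. Compound 1 `COc1ccc(/C=C/C(=O)Nc2nc3ccc([N+](=O)[O-])cc3s2)cc1` gives 315 umol/kg, compound 2 `COc1ccc(/C=C/C(=O)Nc2nc3ccc(Cl)cc3s2)cc1` gives 259 umol/kg and compound 3 `O=C(/C=C/c1ccc(O)cc1)Nc1nc2ccc(Cl)cc2s1` gives 322 umol/kg. Compound 2 therefore stands level with the other two, as both of its measured steps lie within the scatter. Compound 4 `COc1ccc(/C=C/C(=O)Nc2nc3ccc(Cl)cc3s2)cc1O` differs from compound 2 by a single change: hydroxy in place of hydrogen on an aromatic carbon. This is hydroxy in place of hydrogen on an aromatic carbon, ortho to a methoxy group. The closest guide is a 1.2-fold higher number from compound 2 to compound 3 (0.09 log units; within the scatter), where hydrogen replaces methyl on an oxygen on an aromatic ring, giving a small step within the scatter. The other measured step, a 1.2-fold lower number from compound 1 to compound 2 (0.09 log units; within the scatter), is chloro in place of nitro on an aromatic carbon and is also within the scatter, but it bears on this change less directly. Neither step points to a clear direction, so no shift beyond the scatter is expected. The expected change is a 1.1-fold higher number from compound 2 to compound 4 (0.03 log units; within the scatter). For compound 4 the estimated value is 280 umol/kg, with an expected range from 150 umol/kg to 520 umol/kg.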

Compound 4, dose for half-maximal effect: 320 umol/kg
For compound 4 the middle estimate is 1.1-fold (0.06 log units) below the measured one; low and high end bracket the measured number.
By their numbers in this assay, from the lowest: compounds 2, 1, 4 and 3 (each within the scatter of the next).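

Hydroxy in place of hydrogen on an aromatic carbon, ortho to a methoxy group, gives a 1.2-fold higher number from compound 2 to compound 4 (0.09 log units; within the scatter) in this assay, so the first look at this ring position shows no step beyond the scatter. The earlier steps shown here changed the chloro-bearing position and the oxygen of the methoxy group, and a 1.2-fold higher number from compound 2 to compound 3 (0.09 log units; within the scatter) is likewise within the scatter, so a change at any of these three places has so far left the number level. No measurement is at hand that would explain this outcome.

The compounds shown leave open whether an amine or a carboxylic acid at this same aromatic carbon would move the number beyond the scatter. They also leave open whether hydroxy at this place would give the same result with nitro in place of chloro on the core.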